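The compounds below may be only part of what the source reports. "The series", "measured", "known", "first", "only" and "open" are said of these compounds alone.

Compound 1 `Brc1cccc2c1nnn2CC1CC1`: 70 nM
Compound 2 `CCCCn1nnc2c(Br)cccc21`: 60 nM
Compound 3 `CCn1nnc2c(Br)cccc21`: 2240 nM

In a functional assay on cells for positive allosteric modulation of metabotropic glutamate receptor 2 (Homo sapiens), read by fluorescence and calcium flux, with a stated time of 30 min (a lower number here means that less compound is needed, a higher number that more compound is needed for the effect), compound 1 gives 70 nM, the second highest of the three numbers. Its nearest neighbour is seen in a 1.2-fold lower number from compound 1 to compound 2 (0.07 log units; within the scatter), a step within the scatter, while the furthest is seen in a 32-fold higher number from compound 1 to compound 3 (1.51 log units; beyond the scatter), a large step. The third measured step, a 37-fold higher number from compound 2 to compound 3 (1.57 log units; beyond the scatter), is likewise large.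

Compound 4 `Fc1cc(Br)c2nnn(CC3CC3)c2c1` differs from compound 1 by fluoro in place of hydrogen on an aromatic carbon. Among the measured compounds shown here, all three measured steps alter the group on the saturated chain carbon bound to the aromatic nitrogen; none alters a substituent on the six-membered aromatic ring of the shared core, so no measured step bears directly on this change. With no guidance from the measured steps, no step beyond the scatter is expected in this assay. Compound 4 is therefore estimated at 70 nM, with a range from 25 nM to 200 nM. The expected step is no change at the digits printed from compound 1 to compound 4 (within the scatter).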

Compound 4, half-maximal effective concentration: 70 nM
The estimate for compound 4 equals the measured number at the digits printed, and the stated range covers the measured number.
By their numbers in this assay, from the lowest: compounds 2, 1 and 4 (each within the scatter of the next); then compound 3.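

The earlier compounds shown here changed only the group on the saturated chain carbon bound to the aromatic nitrogen, whereas compound 4 carries its change on an aromatic carbon of the six-membered ring. In this assay, fluoro in place of hydrogen at this carbon, meta to a bromo group and para to a fused ring, gives no change at the digits printed from compound 1 to compound 4 (within the scatter), so this change stays within the scatter, unlike the large chain step seen in a 32-fold higher number from compound 1 to compound 3 (1.51 log units; beyond the scatter). Nothing available explains why the number holds at this position.

The compounds shown leave open whether a chloro group, a methoxy group or an amine at this aromatic carbon would also stay within the scatter. They also leave open whether fluoro here would give the same result alongside the chains of compound 2 and compound 3.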